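Demethylation of the methoxy group in compound 2

This account rests on a few compounds, and the source may have more. Where it says the series, first, only, none or still open, it means among the compounds named here.

Measured compounds:
compound 1, `O=C(Nc1cccc(-n2cc(-c3ccncc3)c(-c3ccc(Cl)c(O)c3)n2)c1)Nc1cccc(C(F)(F)F)c1`, 1590 nM
compound 2, `COc1cc(-c2nn(-c3cccc(NC(=O)Nc4ccc(Cl)c(C(F)(F)F)c4)c3)cc2-c2ccncc2)ccc1Cl`, 985 nM

In a functional assay on U-251 cells (Homo sapiens) for inhibition, read by sulforhodamine B assay, with a stated time of 48 h (on this read-out lower numbers stand for stronger inhibition of growth and higher numbers for weaker inhibition of growth), compound 2 gives 985 nM, the lower of the two numbers, while compound 1 gives 1590 nM; the gap between them lies within the scatter, so neither stands apart. Compound 3, `O=C(Nc1cccc(-n2cc(-c3ccncc3)c(-c3ccc(Cl)c(O)c3)n2)c1)Nc1ccc(Cl)c(C(F)(F)F)c1`, differs from compound 2 by hydrogen in place of methyl on an oxygen on an aromatic ring. Within the data shown here, no measured pair shows this change, so the author expects the step from compound 2 to compound 3 to stay small, with no direction beyond the scatter, estimated as a 1.1-fold higher number from compound 2 to compound 3 (0.05 log units; within the scatter). For compound 3 the author estimates 1100 nM, within a range of 400 nM to 3000 nM.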

Compound 3, concentration for 50% growth inhibition: 548 nM
Estimate against measurement, compound 3: 2.0-fold (0.30 log units) above, within the range that was stated.
By their numbers in this assay, from the lowest: compounds 3, 2 and 1 (each within the scatter of the next, the first and the last beyond it).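

In this assay, methoxy to hydroxy on the aromatic ring gives a 1.8-fold lower number from compound 2 to compound 3 (0.25 log units; within the scatter), so at this position the methyl on the oxygen can be lost with no step beyond the scatter. Among these compounds, with that hydroxy in both compounds, chloro in place of hydrogen on an aromatic carbon gives a 2.9-fold lower number from compound 1 to compound 3 (0.46 log units; beyond the scatter), the first step here to pass the scatter. Nothing available explains either step. On these data alone, it remains open whether an ethoxy or an amine at the hydroxy position would keep this level of growth inhibition. As far as these compounds go, it is equally open whether bromo or methyl could stand in for the added chloro.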